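This account rests on a few compounds, and the source may have more. Where it says the series, first, only, none or still open, it means among the compounds named here.

Three close relatives built on two related cores have been measured in a functional assay on HeLa cells (Homo sapiens) for cytotoxicity, read by MTT assay, with a stated time of 72 h; a higher number here means a weaker inhibitor, a lower number a stronger inhibitor. Compound 1 `O=[N+]([O-])c1ccc(/N=N/Nc2ccc([N+](=O)[O-])cc2Br)c(Br)c1` gives 940 nM in this assay. Compound 2 `CC(=O)N(/N=N/c1ccc([N+](=O)[O-])cc1Br)c1ccc([N+](=O)[O-])cc1Br` differs from compound 1 in one place, (acetyl in place of hydrogen on a nitrogen on an aromatic ring), and in this assay compound 2 gives 550 nM. That change made a 1.7-fold lower number from compound 1 to compound 2 (0.23 log units; within the scatter), a step that stays inside the usual spread of repeated measurements, so the two values cannot be ranked. Compound 3 `O=[N+]([O-])c1ccc(/N=N/Nc2ccc([N+](=O)[O-])cc2Cl)c(Cl)c1` rests on a second core; how the core of compound 3 differs from the core of compound 1 is not broken down here. In this assay compound 3 gives 3010 nM, the highest of the three numbers, and its gaps to compound 1 and to compound 2 both lie beyond the scatter.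

Compound 4 `CC(=O)N(/N=N/c1ccc([N+](=O)[O-])cc1Cl)c1ccc([N+](=O)[O-])cc1Cl` has not yet been measured. It stands to compound 3 as compound 2 stands to compound 1: acetyl in place of hydrogen on a nitrogen on an aromatic ring. The place of the change reads the same, word for word, in both pairs, so this is the same change made on two cores, and among the compounds shown it occurs twice. Among the measured compounds shown here, the only guide to its size is the first pair, where the same change made a 1.7-fold lower number from compound 1 to compound 2 (0.23 log units; within the scatter). The step expected on the second core is a 1.7-fold lower number from compound 3 to compound 4 (0.22 log units; within the scatter). Compound 4 is therefore expected to give about 1800 nM in this assay, most likely somewhere between 900 nM and 3600 nM.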

Compound 4, half-maximal inhibitory concentration: 630 nM
The estimate for compound 4 lay 2.9-fold (0.46 log units) above the measured number, outside the stated range (below it).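

In this assay, putting acetyl in place of the hydrogen on the nitrogen gave a 4.8-fold lower number from compound 3 to compound 4 (0.68 log units; beyond the scatter) on the second core, a step that lies beyond the usual scatter of repeated measurements. The same change therefore cannot be carried from one core to the other with its size intact, and a step measured on one core proved a poor guide to the step on the other: the same change on two cores in this assay, a 1.7-fold lower number (0.23 log units; within the scatter) from compound 1 to compound 2 and a 4.8-fold lower number (0.68 log units; beyond the scatter) from compound 3 to compound 4, 2.8-fold (0.45 log units) apart, beyond the scatter of two such steps. This does not show why the two cores respond differently, and two pairs are too few to give a rule for how the change would behave on any further core.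

Only hydrogen and acetyl appear on this nitrogen among the compounds shown, so it remains open whether the gap between the cores belongs to acetyl alone or extends to other groups in that place. A longer chain such as propanoyl, a benzoyl group or a simple methyl group on both cores would test this, by showing whether the steps again differ from one core to the other.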